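The compounds below may be only part of what the source reports. "The series", "measured", "known", "first", "only" and "open" are said of these compounds alone.

Measured in a functional assay on A549 cells (Homo sapiens) for antiproliferative activity, read by MTT assay, with a stated time of 72 h; on this read-out lower numbers stand for stronger inhibition and higher numbers for weaker inhibition:
- compound 1 `O=C1COc2ccc(-c3cnc(Cl)c(NS(=O)(=O)c4ccc(F)cc4)c3)cc2N1C1CCCCC1`: 37900 nM
- compound 2 `CC(C)N1C(=O)COc2ccc(-c3cnc(Cl)c(NS(=O)(=O)c4ccc(F)cc4)c3)cc21`: 5100 nM

Of these two, compound 2 has the lower number and so the stronger inhibition. The next compound, compound 3 `O=C1COc2ccc(-c3cnc(Cl)c(NS(=O)(=O)c4ccc(F)cc4)c3)cc2N1c1ccc(F)cc1`, puts 4-fluorophenyl in place of isopropyl on an amide-type nitrogen in a ring. For the measured compounds named here, only one measured step bears on this position, the change of cyclohexyl to isopropyl, which gave a 7.4-fold lower number from compound 1 to compound 2 (0.87 log units; beyond the scatter). Compound 3 again carries a six-membered ring on that nitrogen, as compound 1 does at 37900 nM, so weaker inhibition than for compound 2 seems likely. That ring is aromatic, however, and a single step is thin evidence, so the range stays wide. The expected change is a 2.7-fold higher number from compound 2 to compound 3 (0.44 log units; beyond the scatter), towards a higher number. For compound 3 the estimated value is 14000 nM, with an expected range from 3500 nM to 45000 nM.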

Compound 3, half-maximal inhibitory concentration: 22300 nM
Estimate against measurement, compound 3: 1.6-fold (0.20 log units) below; the range from low to high includes it.
By their numbers in this assay, from the lowest: compound 2; then compounds 3 and 1 (each within the scatter of the next).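

For the compounds shown here, replacing isopropyl with 4-fluorophenyl on the ring nitrogen weakens inhibition, with a 4.4-fold higher number from compound 2 to compound 3 (0.64 log units; beyond the scatter) in this assay, so the step from cyclohexyl to isopropyl is not the only change at this position that moves the number beyond the scatter. Going from the non-aromatic ring to the aromatic one gives a 1.7-fold lower number from compound 1 to compound 3 (0.23 log units; within the scatter), so the two six-membered rings cannot be told apart here, and isopropyl remains the best of the three groups shown. No measurement offered here explains these differences.

Still open, on these data alone, is whether a methyl group or a longer chain such as n-butyl on this nitrogen would match or beat isopropyl. Also open, as far as these compounds go, is whether an unsubstituted phenyl ring would behave like 4-fluorophenyl, and whether a chain ending in an amine or a carboxylic acid would be tolerated here.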